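This account rests on a few compounds, and the source may have more. Where it says the series, first, only, none or still open, it means among the compounds named here.

Compound 1 `O=S(=O)(c1ccc(F)cc1)c1cc(F)c(O)c2ncccc12` gives 3.5 L/kg
Compound 2 `O=S(=O)(c1cc(F)c(O)c2ncccc12)C1CCCC1` gives 0.41 L/kg
Compound 3 `O=S(=O)(c1cc(Cl)c(O)c2ncccc12)C1CCCC1` gives 0.3 L/kg

In an ADME assay on the whole organism for pharmacokinetics, with Rattus norvegicus as the target (on this read-out higher numbers stand for wider distribution into tissues and lower numbers for narrower distribution), compound 2 stands at the low end together with compound 3, the two lying within the scatter of each other, and far from compound 1. The next compound, compound 4 `O=S(=O)(c1cc(F)c(O)c2ncccc12)N1CCCC1`, keeps the core of compound 2 and changes one group on a sulfonyl sulfur, with pyrrolidin-1-yl in place of cyclopentyl (pyrrolidin-1-yl in place of cyclopentyl on a sulfonyl sulfur).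

Two measured steps offer guidance. The one at the same place, an 8.5-fold lower number from compound 1 to compound 2 (0.93 log units; beyond the scatter), is large and beyond the scatter, but it replaced 4-fluorophenyl with cyclopentyl. The new swap instead keeps a five-membered non-aromatic ring, so that large step is a poor guide to its size. The other, a 1.4-fold lower number from compound 2 to compound 3 (0.14 log units; within the scatter), swapped fluoro for chloro on an aromatic carbon, a different place, and it stayed within the scatter. For the measured compounds named here, no measured step tests a nitrogen in this ring, so the expectation remains loose. No step beyond the scatter is expected in this assay here.

The estimated change is a 1.0-fold lower number from compound 2 to compound 4 (0.01 log units; within the scatter) and would leave the number close to where it stands. Compound 4 is expected at 0.4 L/kg, with an estimated range from 0.18 L/kg to 0.9 L/kg.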

Compound 4, volume of distribution at steady state: 2.2 L/kg
Compound 4: the middle estimate sits 5.5-fold (0.74 log units) below what was measured; measured number above the stated range.
By their numbers in this assay, from the lowest: compounds 3 and 2 (each within the scatter of the next); then compounds 4 and 1 (each within the scatter of the next).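

In this assay, for the compounds shown here, this place on the sulfonyl sulfur proves far more sensitive than the earlier compounds suggested. Pyrrolidin-1-yl and cyclopentyl are both five-membered non-aromatic rings with the same count of heavy atoms, differing by a single nitrogen in place of a carbon, yet that swap alone gives a 5.4-fold higher number from compound 2 to compound 4 (0.73 log units; beyond the scatter) and is beyond the scatter. The large gap between compound 1 and compound 2 therefore cannot be read as simply the loss of an aromatic ring, since the non-aromatic pyrrolidin-1-yl group gives a 1.6-fold lower number from compound 1 to compound 4 (0.20 log units; within the scatter) and stays within the scatter; no outside measurement accounts for this behaviour.

Still open, on these data alone, is whether the ring matters or only the nitrogen attached to the sulfonyl sulfur, which an open-chain amine such as diethylamino or a second ring such as morpholin-4-yl at this place could help to separate. Also open, as far as these compounds go, is whether chloro in place of fluoro on the aromatic carbon, seen so far only with cyclopentyl, would stay within the scatter alongside pyrrolidin-1-yl.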